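The source may report more compounds than this note shows. Statements on the series, on what has been measured and on what is new or still open speak of the compounds shown alone.

Of the compounds shown here, three with a shared core have been tested in an assay for inhibition of Tryptophan 2,3-dioxygenase (Homo sapiens), with stated times of 10 min and 60 min, tested at 10 uM; a higher number here means a stronger effect of the compound at the concentration tested, a lower number a weaker effect. Compound 1 `Oc1ccc(CNc2cc(C(F)(F)F)cc3[nH]ncc23)cc1` gives 75%, compound 2 `FC(F)(F)c1cccc(CNc2cc(C(F)(F)F)cc3[nH]ncc23)c1` gives 40%, and compound 3 `FC(F)(F)c1cc(NC[C@@H]2CCCCN2)c2cn[nH]c2c1` gives 64%. On these numbers compound 3 stands second of the three: its nearest neighbour is compound 1, whose number lies higher, and compound 2 lies furthest, with the lower number. Among the compounds with values here, the only measured step that starts from an aryl-bearing analogue is a number 11 percentage points lower from compound 1 to compound 3 (beyond the scatter), a modest loss on moving to the saturated ring.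

Compound 4 `Nc1cccc(CNc2cc(C(F)(F)F)cc3[nH]ncc23)c1` has not yet been measured. It differs from compound 3 as 3-aminophenyl in place of piperidin-2-yl on a saturated chain carbon bound to a nitrogen on an aromatic ring. The step bearing on this is the reverse of a number 11 percentage points lower from compound 1 to compound 3 (beyond the scatter), in which a return to an aromatic ring carrying a hydrogen-bond donor recovered a modest amount; compound 2, the aryl analogue without such a donor, sits lower. Taken together, compound 4 is expected to land close to compound 1 and compound 3, giving an estimated step of a number 2 percentage points higher from compound 3 to compound 4 (within the scatter) that is not beyond the scatter. The estimate for compound 4 in this assay is 66%, with a range from 45% to 82%.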

Compound 4, a percentage reported as inhibition, at one concentration (the size of the read-out at that concentration, not a potency): 68%
Estimate against measurement, compound 4: 2 percentage points below; the range from low to high includes it.
By their numbers in this assay, from the lowest: compound 2; then compounds 3, 4 and 1 (each within the scatter of the next, the first and the last beyond it).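

In this assay the change from the saturated ring to an aromatic one carrying an amino group gives a number 4 percentage points higher from compound 3 to compound 4 (within the scatter) and the change from 4-hydroxyphenyl gives a number 7 percentage points lower from compound 1 to compound 4 (within the scatter) so on the saturated chain carbon 3-aminophenyl cannot be told apart from either piperidin-2-yl or 4-hydroxyphenyl. By contrast, amino in place of trifluoromethyl on an aromatic carbon gives a number 28 percentage points higher from compound 2 to compound 4 (beyond the scatter) and this shows that the group carried by the aromatic ring can move the number by much more than the exchange of 3-aminophenyl for piperidin-2-yl does. No evidence is available to explain these steps.

The compounds shown leave open whether the place of the group on the aromatic ring matters, which 4-aminophenyl or 3-hydroxyphenyl could separate from the identity of the group. They also leave open how a carboxylic acid on that ring, or a longer chain to it, would read, and each number here reflects one concentration rather than a potency.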